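Halogen swap on the shared core in an L6 cell assay

The source may hold more compounds than are shown below. What is called first, only, known or untested is meant among the compounds shown, and "the series" means these compounds.

In an ADME assay on L6 cells (Rattus norvegicus) for inhibition, read by resazurin assay, with a stated time of 72 h (on this read-out lower numbers stand for stronger inhibition and higher numbers for weaker inhibition), the measured compounds give:
Compound 1, `C[S+]([O-])C[C@H]1O[C@@H](n2cnc3c(N)nc(F)nc32)[C@H](O)[C@@H]1O`: 13000 nM
Compound 2, `C[S+]([O-])C[C@H]1O[C@@H](n2cnc3c(N)nc(Cl)nc32)[C@H](O)[C@@H]1O`: 259000 nM
Compound 3, `CC(=O)O[C@@H]1[C@H](OC(C)=O)[C@@H](CN2C(=O)c3ccccc3C2=O)O[C@H]1n1cnc2c(N)nc(F)nc21`: 129000 nM

Compound 2 differs from compound 1 by one change, (chloro in place of fluoro on an aromatic carbon), and in this assay that change made a 20-fold higher number from compound 1 to compound 2 (1.30 log units; beyond the scatter). Compound 3 sits second highest of the three numbers; against compound 2 it lies within the scatter, against compound 1 it is beyond it. The difference between the core of compound 3 and the core of compound 1 is not broken down here.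

Compound 4, `CC(=O)O[C@@H]1[C@H](OC(C)=O)[C@@H](CN2C(=O)c3ccccc3C2=O)O[C@H]1n1cnc2c(N)nc(Cl)nc21`, is not yet measured. It differs from compound 3 by chloro in place of fluoro on an aromatic carbon, the same change that separates compound 2 from compound 1, at a place described in the same words. Within the data shown here, for this assay the step from compound 3 to compound 4 is expected to be a 7.0-fold higher number from compound 3 to compound 4 (0.84 log units; beyond the scatter), set beside a 20-fold higher number from compound 1 to compound 2 (1.30 log units; beyond the scatter) because a 20-fold higher number from compound 1 to compound 2 (1.30 log units; beyond the scatter) is the only guide available for this change. Compound 4 is therefore estimated at 900000 nM, with a range from 200000 nM to 4000000 nM; so high a number may be reported only as a limit.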

Compound 4, half-maximal inhibitory concentration: 144000 nM
Compound 4: the middle estimate sits 6.3-fold (0.80 log units) above what was measured; measured number below the stated range.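

In this assay, chloro in place of fluoro on an aromatic carbon gives a 1.1-fold higher number from compound 3 to compound 4 (0.05 log units; within the scatter), so the change that counted for much on the core of compound 1 leaves no readable mark on the core of compound 3. The size of this step did not carry from one core to the other: the same change on two cores in this assay, a 20-fold higher number (1.30 log units; beyond the scatter) from compound 1 to compound 2 and a 1.1-fold higher number (0.05 log units; within the scatter) from compound 3 to compound 4, 18-fold (1.25 log units) apart, beyond the scatter of two such steps. This shows that, in these two pairs, the effect of the change depends on the core that carries it, but it does not show which part of the core matters, as the difference between the two cores is not broken down.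

From the compounds shown here alone, it remains open how bromo, methoxy or a methyl group on that same aromatic carbon would read on either core. Going by these compounds, it is also open whether a third core would behave like the pair compound 1 and compound 2 or like the pair compound 3 and compound 4.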